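A few compounds are considered here, and "the series" means these few. Any claim that something is new, unique, unknown or untested is made for them only; others in the source may bear on it.

Working notes on the series. Compound 1 `COc1ccnc(Nc2ccc(Cl)c(OCC=C(C)C)c2)n1` gives 9000 nM in a functional assay on MT2 cells (Homo sapiens) for cytotoxicity; a lower number here means that less compound is tolerated, a higher number that more compound is tolerated. Within the data shown here, compound 3 `CC(C)=CCOc1cc(Nc2nccc(C(F)(F)F)n2)ccc1Cl` gives 2500 nM in this assay, and the step of a 3.6-fold lower number from compound 1 to compound 3 (0.56 log units; beyond the scatter) is the only change in the set with a measured consequence. Compound 2 `CC(C)=CCOc1cc(Nc2nccs2)ccc1C(C)C` gives 31000 nM in this assay, the highest of the three numbers, beyond the scatter from compound 1 and further still from compound 3.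

Compound 4 `CCCc1ccc(Nc2nccs2)cc1OCC=C(C)C` is not yet measured. Relative to compound 2 the change is propyl in place of isopropyl on an aromatic carbon. Among the measured compounds shown here, no measured pair varies this position, and the single measured step, a 3.6-fold lower number from compound 1 to compound 3 (0.56 log units; beyond the scatter), concerns a group on the heteroaryl part of a different core, so it does not bear on a rearrangement of the same atoms at the carbon ring. Nothing in the set therefore argues for movement in either direction. The step from compound 2 to compound 4 is expected to be no change at the digits printed from compound 2 to compound 4 (within the scatter), none beyond the scatter. Compound 4 is estimated at 31000 nM, with a range from 12000 nM to 80000 nM.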

Compound 4, half-maximal cytotoxic concentration: 23000 nM
The estimate for compound 4 lay 1.3-fold (0.13 log units) above the measured number; the range from low to high includes it.
By their numbers in this assay, from the lowest: compound 3; then compound 1; then compounds 4 and 2 (each within the scatter of the next).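

Among these compounds, the step of a 1.3-fold lower number from compound 2 to compound 4 (0.13 log units; within the scatter) gives the first measured reading at this position, on the aromatic carbon ortho to the (3-methylbut-2-en-1-yl)oxy group and para to the (1,3-thiazol-2-yl)amino group. In this assay, exchanging isopropyl for propyl, two groups with the same atoms joined differently, does not separate the two compounds, so this rearrangement leaves the tolerated concentration unresolved from that of the parent. No measurement at hand accounts for this result.

Still open, as far as these compounds go, is whether a group of a different kind at this position, such as a longer chain, an amine or a carboxylic acid, would shift the number beyond the scatter. Also open, from the compounds shown here alone, is whether the same exchange of isopropyl for propyl would read alike with another group on the amino nitrogen, such as the trifluoromethyl-bearing heteroaryl of compound 3.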